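This account rests on a few compounds, and the source may have more. Where it says the series, first, only, none or still open, it means among the compounds named here.

In an ADME assay on Vero cells (Chlorocebus sabaeus) for cytotoxicity, read by MTT assay, with a stated time of 72 h (on this read-out higher numbers stand for lower toxicity in this test and lower numbers for higher toxicity in this test), compound 1 `CCc1nc2cc(Cl)ccn2c1C(=O)NCc1ccc2c(c1)CCN(Cc1ccc(OC)cc1)C2` gives 32 ug/mL and compound 2 `CCc1nc2ccc(Cl)cn2c1C(=O)NCc1ccc2c(c1)CCN(Cc1cc(F)cc(F)c1)C2` gives 14 ug/mL. Compound 3 `CCc1nc2ccc(Cl)cn2c1C(=O)NCc1ccc2c(c1)CCN(Cc1ccc(C(F)(F)F)cn1)C2` reads > 64 ug/mL, which is a limit of the assay and not a number. Compound 4 `CCc1nc2ccc(Cl)cn2c1C(=O)NCc1ccc2c(c1)CCN(Cc1ccc(C)cc1)C2` differs from compound 3 by one change (4-methylphenyl in place of 5-(trifluoromethyl)pyridin-2-yl on a saturated chain carbon bound to an amine nitrogen in a ring), with 4-methylphenyl in place of 5-(trifluoromethyl)pyridin-2-yl. Going by the values given here, the one measured step that bears on this is an at least 4.5-fold higher number from compound 2 to compound 3 (0.66 log units; beyond the scatter), where 5-(trifluoromethyl)pyridin-2-yl replaced 3,5-difluorophenyl. Compound 4 returns to a carbon-only ring, as compound 2 has at 14 ug/mL, so that step is expected to reverse, beyond the scatter. The estimated step is an at least 2.9-fold lower number from compound 3 to compound 4 (0.46 log units; beyond the scatter), meaning a lower number and higher toxicity in this test. For compound 4 the estimate is 22 ug/mL, expected between 9 ug/mL and 55 ug/mL.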

Compound 4, half-maximal cytotoxic concentration: 51 ug/mL
The estimate for compound 4 lay 2.3-fold (0.37 log units) below the measured number; the range from low to high includes it.
By their numbers in this assay, from the lowest: compound 2; then compounds 1 and 4 (each within the scatter of the next). At a limit, above all of these: compound 3.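

In this assay, a ring of carbon only on this saturated chain carbon does not by itself give a low number: a 3.6-fold higher number from compound 2 to compound 4 (0.56 log units; beyond the scatter). The ring nitrogen of 5-(trifluoromethyl)pyridin-2-yl is therefore not needed for a number well clear of the one for 3,5-difluorophenyl. The other step reads an at least 1.2-fold lower number from compound 3 to compound 4 (0.09 log units; that floor lies within the scatter), and its floor lies within the scatter because compound 3 stands at a limit: the limit of > 64 ug/mL in this assay, at which 1 of the 4 values shown sits.

As far as these compounds go, how far compound 3 truly lies from compound 4 stays open. So does how an amine or a carboxylic acid in place of the methyl of 4-methylphenyl would read.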